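Swapping the methoxy ring for a difluoro ring

A few compounds are considered here, and "the series" means these few. Any claim that something is new, unique, unknown or untested is made for them only; others in the source may bear on it.

Compound 2 `COc1ccc(C(=O)/C=C/c2cc(-c3cc(OC)c(OC)c(OC)c3)n[nH]2)cc1` gives 83% in a functional assay on NCI-H522 cells (Homo sapiens) for cytotoxicity, read by sulforhodamine B assay, with a stated time of 48 h, tested at 0.01 uM (on this read-out lower numbers stand for a stronger effect and higher numbers for a weaker effect at the one concentration tested), level with compound 1 `COc1ccc(C(=O)/C=C/c2cc(-c3cc(OC)c(OC)c(OC)c3)n[nH]2)cc1OC`, which gives 83%. The step of no change at the digits printed from compound 1 to compound 2 (within the scatter), where the ring attached to the carbonyl lost one methoxy, left the read-out unchanged. Compound 3 `COc1cc(-c2cc(/C=C/C(=O)c3ccc(F)c(F)c3)[nH]n2)cc(OC)c1OC` differs from compound 2 by 3,4-difluorophenyl in place of 4-methoxyphenyl on a carbonyl carbon. For the measured compounds named here, no measured step covers a difluoro replacement; the only related step, at the same ring, was flat. The step is therefore expected to stay small, a number 1 percentage points lower from compound 2 to compound 3 (within the scatter), and compound 3 is estimated at 82%, between 65% and 100%.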

Compound 3, a percentage reported as activity, at one concentration (the size of the read-out at that concentration, not a potency): 96%
Compound 3: middle estimate off by 14 percentage points, on the low side; measured number inside the range.
By their numbers in this assay, from the lowest: compounds 1 and 2 (each within the scatter of the next); then compound 3.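

In this assay, the ring on the carbonyl carbon proves sensitive to change: 3,4-difluorophenyl in place of 4-methoxyphenyl gives a number 13 percentage points higher from compound 2 to compound 3 (beyond the scatter), and in place of 3,4-dimethoxyphenyl it gives a number 13 percentage points higher from compound 1 to compound 3 (beyond the scatter), in each case a weaker effect. Removing one methoxy had moved nothing, so this position does not accept every change equally. No measurement here explains the shift.

The compounds shown cannot separate the effect of adding the fluorines from that of losing the remaining methoxy, which a plain phenyl ring could address. As far as these compounds go, how an amine or a carboxylic acid on this ring would behave also remains open.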